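Working notes: from compound 3 to compound 4

The source may hold more compounds than are shown below. What is called first, only, known or untested is meant among the compounds shown, and "the series" means these compounds.

Measured in an ADME assay on MDCK-II cells (Canis lupus familiaris) for permeability; a higher number here means that the compound crosses the layer faster, a lower number that the compound crosses the layer more slowly:
- compound 1 `Cc1ccc(NC(=O)c2cc(Oc3ccc(S(C)(=O)=O)cc3)cc(OC(C)C)c2)nc1`: 4.4 10^-6 cm/s
- compound 2 `CC(C)Oc1cc(Oc2ccc(S(C)(=O)=O)cc2)cc(-c2nccc(=O)[nH]2)c1`: 24 10^-6 cm/s
- compound 3 `Cc1cnc(-c2cc(Oc3ccc(S(C)(=O)=O)cc3)cc(OC(C)C)c2)[nH]c1=O`: 17 10^-6 cm/s

Compound 3 stands within the scatter of compound 2 and clearly higher than compound 1. Compound 4 `Cc1cc(=O)[nH]c(-c2cc(Oc3ccc(S(C)(=O)=O)cc3)cc(OC(C)C)c2)n1` has the same atoms as compound 3, joined differently: a group of 8 heavy atoms (5 carbon, 2 nitrogen, 1 oxygen; one six-membered aromatic ring with 2 hetero atoms) in place of a group of 8 heavy atoms (5 carbon, 2 nitrogen, 1 oxygen; one six-membered aromatic ring with 2 hetero atoms), on an aromatic carbon. The closest evidence is a 1.4-fold lower number from compound 2 to compound 3 (0.15 log units; within the scatter), a methyl in place of hydrogen that stays within the scatter. The larger steps, a 5.5-fold higher number from compound 1 to compound 2 (0.74 log units; beyond the scatter) and a 3.9-fold higher number from compound 1 to compound 3 (0.59 log units; beyond the scatter), exchange a group of 10 heavy atoms and bear on this change less directly. No step beyond the scatter is therefore expected in this assay, and no direction is favoured. The estimated step is a 1.1-fold higher number from compound 3 to compound 4 (0.02 log units; within the scatter). Compound 4 is expected at 18 10^-6 cm/s, with an estimated range of 10 10^-6 cm/s to 30 10^-6 cm/s.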

Compound 4, apparent permeability: 4.8 10^-6 cm/s
Estimate against measurement, compound 4: 3.8-fold (0.57 log units) above, and the stated range ends above it.
By their numbers in this assay, from the lowest: compounds 1 and 4 (each within the scatter of the next); then compounds 3 and 2 (each within the scatter of the next).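

In this assay the place of the methyl on the ring with 2 hetero atoms counts: one placement gives a 1.4-fold lower number from compound 2 to compound 3 (0.15 log units; within the scatter) and the other gives a 5.0-fold lower number from compound 2 to compound 4 (0.70 log units; beyond the scatter) and a 3.5-fold lower number from compound 3 to compound 4 (0.55 log units; beyond the scatter) as well. A ring of this kind therefore does not by itself carry the higher numbers, and a 1.1-fold higher number from compound 1 to compound 4 (0.04 log units; within the scatter) shows no separation from the group it replaces.

Going by these compounds, whether an ethyl group or a methoxy group on the carbon holding the methyl in compound 4 would behave like that methyl stays open. No measurement at hand accounts for the difference between the two isomers.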